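This account rests on a few compounds, and the source may have more. Where it says the series, first, only, none or still open, it means among the compounds named here.

Of the compounds shown here, two with the same core have been measured in a functional assay on MIA PaCa-2 cells (Homo sapiens) for antiproliferative activity, read by luminescence, with a stated time of 72 h; on this read-out lower numbers stand for stronger inhibition and higher numbers for weaker inhibition. There, compound 1 `CN1CC=C(c2c(O)cc(O)c3c(=O)cc(-c4ccc(Sc5nc6ccccc6[nH]5)cc4)oc23)CC1` gives 852 nM, while compound 2 `CN1CC=C(c2c(O)cc(O)c3c(=O)cc(-c4ccc(Sc5nc6ccccc6n5C)cc4Cl)oc23)CC1` gives 52.9 nM. Compound 2 therefore holds the lower of the two numbers, and the gap between them lies beyond the usual scatter.

Compound 3 `CN1CC=C(c2c(O)cc(O)c3c(=O)cc(-c4ccc(Sc5nc6ccccc6[nH]5)cc4Cl)oc23)CC1` departs from compound 2 in one place, where 1-methyl-1H-benzimidazol-2-yl becomes 1H-benzimidazol-2-yl: hydrogen in place of methyl on an aromatic nitrogen. In words, this is hydrogen in place of methyl on an aromatic nitrogen. Going by the values given here, no measured pair shows this change alone, so any forecast is uncertain.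

The expectation leans on compound 1, which also has hydrogen on that nitrogen and gives 852 nM. Compound 3 is thus expected to lose some activity in this assay, moving to a higher number, though not necessarily as far as compound 1. The expected change is a 2.8-fold higher number from compound 2 to compound 3 (0.45 log units; beyond the scatter), a modest step whose size remains an estimate. For compound 3 the estimated half-maximal inhibitory concentration is 150 nM, with an expected range from 45 nM to 550 nM.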

Compound 3, half-maximal inhibitory concentration: 361 nM
For compound 3 the middle estimate is 2.4-fold (0.38 log units) below the measured one, within the range that was stated.
By their numbers in this assay, from the lowest: compound 2; then compound 3; then compound 1.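

Going by these compounds alone, with compound 3 in place, the methyl on the aromatic nitrogen can be read alone for the first time: in this assay, removing it gives a 6.8-fold higher number from compound 2 to compound 3 (0.83 log units; beyond the scatter), so this position is not indifferent to the change, at least with the chloro group present. The same compound also isolates the chloro group, since adding chloro in place of hydrogen on an aromatic carbon gives a 2.4-fold lower number from compound 1 to compound 3 (0.37 log units; beyond the scatter), and both changes therefore count separately, with the methyl step the larger of the two. Nothing available explains why either change moves the number in this way.

The compounds shown leave open whether the methyl step keeps its size when the chloro group is absent, since the only compounds here that carry hydrogen on that nitrogen, compound 1 and compound 3, say nothing about methyl without chloro. They also leave open whether a longer chain such as ethyl or 2-methoxyethyl on the same nitrogen would continue the trend or reverse it, and whether fluoro or methoxy could stand in for the chloro group.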